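Compound 3 and an unmeasured ring swap

A few compounds are considered here, and "the series" means these few. Any claim that something is new, unique, unknown or untested is made for them only; others in the source may bear on it.

Compound 1 `N#Cc1ccc2c(c1)C(n1ccccc1=O)=CC(CF)(CF)O2`: 24.6 nM
Compound 2 `O=c1ccccn1C1=CC(CF)(CF)Oc2ccc([N+](=O)[O-])cc21`: 2.46 nM
Compound 3 `O=c1ccccn1C1=CC(CF)(CF)Oc2ccc(C(F)(F)C(F)(F)F)cc21`: 2.95 nM

The three compounds were measured in a functional assay (aorta) with Rattus norvegicus as the target (a higher number here means that more compound is needed for the effect, a lower number that less compound is needed), and they differ only in one group on an aromatic carbon. Compound 3, with its 1,1,2,2,2-pentafluoroethyl group, stands level with compound 2, as a 1.2-fold higher number from compound 2 to compound 3 (0.08 log units; within the scatter) shows. It stands clearly below compound 1, with an 8.3-fold lower number from compound 1 to compound 3 (0.92 log units; beyond the scatter).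

Compound 4 `[O-][n+]1ccccc1C1=CC(CF)(CF)Oc2ccc(C(F)(F)C(F)(F)F)cc21` keeps that 1,1,2,2,2-pentafluoroethyl group and changes the shared core elsewhere: a group of 7 heavy atoms (5 carbon, 1 nitrogen, 1 oxygen; one six-membered aromatic ring with 1 hetero atom) in place of a group of 7 heavy atoms (5 carbon, 1 nitrogen, 1 oxygen; one six-membered aromatic ring with 1 hetero atom), on a double-bonded ring carbon. The change lies on a double-bonded ring carbon, two ring bonds from the ring atom that bears two fluoromethyl groups.

Among the compounds with values here, no measured step touches this place. The nearest evidence is a 10-fold lower number from compound 1 to compound 2 (1.00 log units; beyond the scatter) and an 8.3-fold lower number from compound 1 to compound 3 (0.92 log units; beyond the scatter), but both come from the aromatic carbon and say nothing directly about the new group. Within the data shown here, they show only that one exchange in this small series can move the number well beyond the scatter, so the range must stay wide. With no measured guide to a direction, no shift beyond the scatter is expected in this assay. The expected change is a 1.2-fold higher number from compound 3 to compound 4 (0.07 log units; within the scatter). For compound 4 the estimated value is 3.5 nM, with an expected range from 0.9 nM to 14 nM.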

Compound 4, half-maximal effective concentration: 1.7 nM
Beside the measured number, compound 4's estimate is 2.1-fold (0.31 log units) above it; the range from low to high includes it.
By their numbers in this assay, from the lowest: compounds 4, 2 and 3 (each within the scatter of the next); then compound 1.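

Within the data shown here, this is the first measured exchange on the double-bonded ring carbon of the shared core, and in this assay it gives a 1.7-fold lower number from compound 3 to compound 4 (0.24 log units; within the scatter), so this pair shows no shift beyond the scatter at the new position. The two groups hold the same atoms joined differently, and they differ in their counts of hydrogen-bond acceptors and of double bonds outside aromatic rings, yet with the 1,1,2,2,2-pentafluoroethyl group held constant, that rearrangement leaves the number level. No measurement shown here accounts for this outcome or links it to any property of either group.

Going by these compounds, all that is known about this position comes from a single pair carrying the 1,1,2,2,2-pentafluoroethyl group, so it remains open whether the same exchange would leave the number level with the cyano or the nitro group on the aromatic carbon. On these data alone, it also remains open whether a quite different group on the double-bonded ring carbon, such as an amine or a carboxylic acid, would stay within the scatter or move the number well beyond it.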